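A few compounds are considered here, and "the series" means these few. Any claim that something is new, unique, unknown or untested is made for them only; others in the source may bear on it.

Compound 1 `CCc1ccccc1NC(=O)[C@@H]1CCCN1S(=O)(=O)c1cccc2cccnc12` carries a 2-ethylphenyl group on its amide nitrogen. In an ADME assay on HEp-2 cells (Homo sapiens) for cytotoxicity (on this read-out lower numbers stand for higher toxicity in this test and higher numbers for lower toxicity in this test), compound 1 gives only a limit of the assay, > 50000 nM, and not a number; that is the case noted as the limit of > 50000 nM in this assay, at which 1 of the 3 values shown sits. Compound 2 `CC(C)c1ccccc1NC(=O)[C@@H]1CCCN1S(=O)(=O)c1cccc2cccnc12` differs from compound 1 by methyl in place of hydrogen on a saturated chain carbon bound to an aromatic carbon and a saturated chain carbon. In this assay compound 2 gives 29900 nM, which is an at least 1.6-fold lower number from compound 1 to compound 2 (0.22 log units; that floor lies within the scatter). Compound 3 `Cc1ccc(C(C)C)cc1NC(=O)[C@@H]1CCCN1S(=O)(=O)c1cccc2cccnc12` has a different core, and the difference from compound 1 is 5-isopropyl-2-methylphenyl in place of 2-ethylphenyl on an amide-type nitrogen. In this assay compound 3 gives 9700 nM, a value that is an at least 5.1-fold lower number from compound 1 to compound 3 (0.71 log units; beyond the scatter) and a 3.1-fold lower number from compound 2 to compound 3 (0.49 log units; beyond the scatter).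

Compound 4 `Cc1ccc(C(C)(C)C)cc1NC(=O)[C@@H]1CCCN1S(=O)(=O)c1cccc2cccnc12` is not yet measured. It differs from compound 3 by methyl in place of hydrogen on a saturated chain carbon bound to an aromatic carbon and two saturated chain carbons. Within the data shown here, this is the same kind of change as the one from compound 1 to compound 2, though the carbon that takes the methyl is now bound to two saturated chain carbons rather than one. Because that earlier step was an at least 1.6-fold lower number from compound 1 to compound 2 (0.22 log units; that floor lies within the scatter), a small step of about a 1.5-fold lower number from compound 3 to compound 4 (0.17 log units; within the scatter) is expected here. Compound 4 is therefore estimated to give about 6500 nM in this assay.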

Compound 4, half-maximal cytotoxic concentration: 6500 nM
Estimate against measurement, compound 4: no gap at the digits printed; the measured number falls inside the stated range.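

Replacing isopropyl with tert-butyl gives a 1.5-fold lower number from compound 3 to compound 4 (0.17 log units; within the scatter) in this assay, so on the core of compound 3 this single added methyl has no effect that can be told apart from ordinary repeat variation. The same change has now been seen on two cores, and the comparison reads: the same change on two cores in this assay, an at least 1.6-fold lower number (0.22 log units; that floor lies within the scatter) from compound 1 to compound 2 and a 1.5-fold lower number (0.17 log units; within the scatter) from compound 3 to compound 4; the limit leaves it open whether they differ. Compound 1 gives only a limit, so the first step has a floor and no exact size, and the two cases show neither that the change carries over unchanged nor that it does not: the limit of > 50000 nM in this assay, at which 1 of the 4 values shown sits.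

Open, as far as these compounds go, is whether a longer chain, such as n-butyl, or a different kind of group, such as an amine or a carboxylic acid, in place of the tert-butyl group would shift the number further than the steps seen here. Also open, from the compounds shown here alone, is how the same methyl change would behave on a third core, where both members of the pair give exact numbers.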